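Replacing 3-fluorophenyl with 4-chlorophenyl on an amide-type nitrogen

The source may report more compounds than this note shows. Statements on the series, on what has been measured and on what is new or still open speak of the compounds shown alone.

In a functional assay on SEM cells (Homo sapiens) for inhibition, read by MTT assay, with a stated time of 72 h (a higher number here means a weaker inhibitor, a lower number a stronger inhibitor), compound 1 (`COc1cccc(/C=C/C(=O)Nc2cc(OC)c(OC)c(OC)c2)c1`) gives 18200 nM and compound 2 (`C=C(Br)C(=O)Nc1cccc(/C=C/C(=O)Nc2ccc(F)cc2)c1`) gives 8400 nM while compound 3 (`C=C(Br)C(=O)Nc1cccc(/C=C/C(=O)Nc2cccc(F)c2)c1`) gives 620 nM as the lowest of the three numbers, with its gaps to both others beyond the scatter.

The next structure, compound 4 (`C=C(Br)C(=O)Nc1cccc(/C=C/C(=O)Nc2ccc(Cl)cc2)c1`), carries 4-chlorophenyl in place of the 3-fluorophenyl of compound 3 on an amide-type nitrogen (4-chlorophenyl in place of 3-fluorophenyl on an amide-type nitrogen). Among the compounds with values here, only one measured step bears on this change. With 3-fluorophenyl in place of 4-fluorophenyl on an amide-type nitrogen, the record shows a 14-fold lower number from compound 2 to compound 3 (1.13 log units; beyond the scatter) as a large step in favour of the 3-fluorophenyl compound. Compound 4 gives up that same 3-fluorophenyl group, so a higher number is expected in this assay and the step is expected to be beyond the scatter. Within the data shown here, no measured compound carries 4-chlorophenyl, however, so the full size of the earlier step cannot simply be carried over, and a somewhat smaller rise is the working expectation.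

The estimated move is a 4.0-fold higher number from compound 3 to compound 4 (0.61 log units; beyond the scatter) and remains an expectation only. For compound 4 the expected value is 2500 nM within an estimated range from 600 nM to 10000 nM in this measurement.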

Compound 4, half-maximal inhibitory concentration: 1190 nM
The estimate for compound 4 lay 2.1-fold (0.32 log units) above the measured number; the measured number falls inside the stated range.
By their numbers in this assay, from the lowest: compounds 3 and 4 (each within the scatter of the next); then compound 2; then compound 1.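

In this assay the exchange of 3-fluorophenyl for 4-chlorophenyl on an amide-type nitrogen stays within the scatter (a 1.9-fold higher number from compound 3 to compound 4 (0.28 log units; within the scatter)), so the large step that favoured the 3-fluorophenyl group over the 4-fluorophenyl group does not mean that any compound without 3-fluorophenyl falls back to the level of compound 2. The identity of the halogen also counts at this site, since chloro in place of fluoro on an aromatic carbon gives a modest step (a 7.1-fold lower number from compound 2 to compound 4 (0.85 log units; beyond the scatter)), and among the three compounds sharing this core, compound 2 is thus the one that stands apart, while compound 3 and compound 4 cannot be told apart. Nothing measured here explains why the chloro and fluoro groups differ in this way.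

The compounds shown leave open how a 3-chlorophenyl group on the same nitrogen would compare, and with it how much of the result belongs to the halogen and how much to where it sits in the group's name. They also leave open whether a 4-bromophenyl or a 4-aminophenyl group would stay with compound 3 and compound 4 or fall back towards compound 2.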